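Adding a Methyl to the Piperidin-1-yl Ring of Compound 2

The source may report more compounds than this note shows. Statements on the series, on what has been measured and on what is new or still open speak of the compounds shown alone.

Three measured compounds share one core. Compound 1 `COc1cc2c(Oc3ccc(NC(=O)c4nnn(-c5ccccc5)c4C)cc3F)ccnc2cc1OCCCN1CCCC1` gives 40 nM in a functional assay on MKN-45 cells (Homo sapiens) for cytotoxicity, read by MTT assay, with a stated time of 72 h; on this read-out higher numbers stand for weaker inhibition and lower numbers for stronger inhibition. Compound 2 `COc1cc2c(Oc3ccc(NC(=O)c4nnn(-c5ccccc5)c4C)cc3F)ccnc2cc1OCCCN1CCCCC1` gives 80 nM in this assay, and compound 3 `COc1cc2c(Oc3ccc(NC(=O)c4nnn(-c5ccccc5C(F)(F)F)c4C)cc3F)ccnc2cc1OCCCN1CCCCC1` gives 90 nM. The number for compound 2 sits in the middle of the three, and both steps that reach it stay within the scatter: a 2.0-fold higher number from compound 1 to compound 2 (0.30 log units; within the scatter), and a 1.1-fold higher number from compound 2 to compound 3 (0.05 log units; within the scatter).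

Compound 4 `COc1cc2c(Oc3ccc(NC(=O)c4nnn(-c5ccccc5)c4C)cc3F)ccnc2cc1OCCCN1CCC(C)CC1` is compound 2 with one small change: methyl in place of hydrogen on a saturated ring carbon. Within the data shown here, no measured step places a methyl on this ring, so nothing bears on it directly. The two measured steps, one enlarging the ring at the chain end and one adding trifluoromethyl on an aromatic carbon, both produced steps within the scatter, which suggests the numbers here move little under small changes. For compound 4 the expected step is therefore no change at the digits printed from compound 2 to compound 4 (within the scatter), none beyond the scatter. The estimate for compound 4 in this assay is 80 nM, with a range from 35 nM to 180 nM.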

Compound 4, half-maximal inhibitory concentration: 90 nM
Estimate against measurement, compound 4: 1.1-fold (0.05 log units) below; low and high end bracket the measured number.
By their numbers in this assay, from the lowest: compounds 1, 2, 3 and 4 (each within the scatter of the next, the first and the last beyond it).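

In this assay, among these compounds, methyl on a saturated ring carbon, three ring bonds from the ring nitrogen, gives a 1.1-fold higher number from compound 2 to compound 4 (0.05 log units; within the scatter), so this ring carbon carries a methyl with no step that stands clear of repeat measurements. Measured against the pyrrolidin-1-yl end of compound 1, the 4-methylpiperidin-1-yl end gives a 2.3-fold higher number from compound 1 to compound 4 (0.35 log units; beyond the scatter), a modest step, whereas plain piperidin-1-yl gave a 2.0-fold higher number from compound 1 to compound 2 (0.30 log units; within the scatter), so the two ring changes together just pass the scatter. No supporting data explain these numbers.

From the compounds shown here alone, whether an ethyl or a hydroxyl group at this same ring carbon would leave the number where it is remains open. So does the result of a morpholin-4-yl ring at the end of the chain.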